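The source may report more compounds than this note shows. Statements on the series, on what has been measured and on what is new or still open speak of the compounds shown alone.

Measured in a functional assay on CEM-DNR-bulk cells (Homo sapiens), read by MTT assay, with a stated time of 72 h; a lower number here means a stronger inhibitor, a higher number a weaker inhibitor:
- compound 1 `CNc1ncnc2c1c(-c1ccoc1)cn2[C@@H]1O[C@H](CO)[C@@H](O)[C@H]1O`: > 20000 nM
- compound 2 `CNc1ncnc2c1c(-c1ccsc1)cn2[C@@H]1O[C@H](CO)[C@@H](O)[C@H]1O`: > 20000 nM

Both entries are limits and not numbers. Compound 2 therefore has no exact position: it shares the limit of > 20000 nM in this assay, at which 2 of the 2 values shown sit, with compound 1. Going by the values given here, the only measured step, a step that the two limits leave unreadable from compound 1 to compound 2, has no readable size, so it offers no measure of how much this position can matter.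

Compound 3 `C#Cc1cn([C@@H]2O[C@H](CO)[C@@H](O)[C@H]2O)c2ncnc(NC)c12` carries ethynyl in place of thiophen-3-yl on an aromatic carbon of the shared core: ethynyl in place of thiophen-3-yl on an aromatic carbon. This replaces the ring with a smaller group that has no ring, a change unlike the swap between the two measured compounds. With no size to carry over, only a modest gain in this assay is expected, and a result at the limit remains likely. The expected change is an at least 1.4-fold lower number from compound 2 to compound 3 (0.15 log units; that floor lies within the scatter). For compound 3 the estimated value is 14000 nM, with an expected range from 2500 nM to 40000 nM.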

Compound 3, half-maximal inhibitory concentration: 18500 nM
For compound 3 the middle estimate is 1.3-fold (0.12 log units) below the measured one; measured number inside the range.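

In this assay, going by these compounds alone, compound 3 gives the first exact number at this position, 18500 nM, with ethynyl, which has no ring, in place of a five-membered aromatic ring. Replacing thiophen-3-yl gives an at least 1.0-fold lower number from compound 2 to compound 3 (0.03 log units; that floor lies within the scatter), and replacing furan-3-yl gives an at least 1.0-fold lower number from compound 1 to compound 3 (0.03 log units; that floor lies within the scatter); these are floors, so the true size of each step stays unknown and no gain beyond the scatter is shown. Compounds 1 and 2 remain limits and not numbers: the limit of > 20000 nM in this assay, at which 2 of the 3 values shown sit.

The step between compounds 1 and 2 still cannot be read, so the two rings cannot be told apart at this position. On these data alone, whether the triple bond matters also stays open, as does the effect of an ethyl group, a longer chain or an amine on this aromatic carbon.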